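Nitro for Fluoro on Two Lactone Cores

The source may report more compounds than this note shows. Statements on the series, on what has been measured and on what is new or still open speak of the compounds shown alone.

Compound 1 `O=C1C=C[C@@H](OCc2ccccc2)[C@@H]([C@@H](COC(=O)/C=C/c2ccc(F)cc2)OCc2ccccc2)O1` and compound 2 `O=C1C=C[C@@H](OCc2ccccc2)[C@@H]([C@@H](COC(=O)/C=C/c2ccc([N+](=O)[O-])cc2)OCc2ccccc2)O1` share one core. In a functional assay on A549 cells (Homo sapiens) for antiproliferative activity, read by MTT assay, with a stated time of 6 days (on this read-out higher numbers stand for weaker inhibition and lower numbers for stronger inhibition), compound 1 gives 12100 nM, while compound 2 gives 5240 nM. The change between them, (nitro in place of fluoro on an aromatic carbon), made a step of a 2.3-fold lower number from compound 1 to compound 2 (0.36 log units; beyond the scatter). Compound 3 `CC(=O)O[C@@H]1C=CC(=O)O[C@@H]1[C@@H](COC(=O)/C=C/c1ccc(F)cc1)OC(C)=O` carries a different core; the difference between the two cores is not broken down here. In this assay compound 3 gives 2120 nM, the lowest of the three numbers. Compound 4 `CC(=O)O[C@@H]1C=CC(=O)O[C@@H]1[C@@H](COC(=O)/C=C/c1ccc([N+](=O)[O-])cc1)OC(C)=O` is not yet measured; it differs from compound 3 by nitro in place of fluoro on an aromatic carbon, the same change that was made from compound 1 to compound 2. Because the step of a 2.3-fold lower number from compound 1 to compound 2 (0.36 log units; beyond the scatter) went beyond the scatter, a step of similar size is expected in this assay, namely a 2.2-fold lower number from compound 3 to compound 4 (0.35 log units; beyond the scatter). Compound 4 is accordingly estimated at 950 nM, most likely between 400 nM and 2200 nM.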

Compound 4, half-maximal inhibitory concentration: 2260 nM
Compound 4: the middle estimate sits 2.4-fold (0.38 log units) below what was measured; measured number above the stated range.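

In this assay, within the data shown here, nitro in place of fluoro on the core of compound 3 gave a 1.1-fold higher number from compound 3 to compound 4 (0.03 log units; within the scatter), so on this core the change produced no step that stands clear of the scatter. Set beside the earlier step on the core of compound 1, the new step cannot be told apart from it: the same change on two cores in this assay, a 2.3-fold lower number (0.36 log units; beyond the scatter) from compound 1 to compound 2 and a 1.1-fold higher number (0.03 log units; within the scatter) from compound 3 to compound 4, 2.5-fold (0.39 log units) apart, within the scatter of two such steps. One pair on each core therefore shows neither that the change carries over from one core to the other nor that the core alters its effect.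

The compounds shown leave open whether an amine or a carboxylic acid on that aromatic carbon would behave alike on both cores. They also leave open whether any other replacement for fluoro would separate the two cores.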